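The compounds below may be only part of what the source reports. "The series", "measured", "known", "first", "only" and "open" are said of these compounds alone.

The series is anchored by compound 1 `O=C(NNc1ccccc1Cl)c1ccc(NS(=O)(=O)c2cnc(O)nc2O)cc1`, which in a functional assay on OVCAR-3 cells (Homo sapiens) for antiproliferative activity, read by MTT assay, with a stated time of 24 h (on this read-out higher numbers stand for weaker inhibition and lower numbers for stronger inhibition), gives 7230 nM. Compound 2 `O=C(NNc1ccccc1Cl)c1ccccc1NS(=O)(=O)c1cnc(O)nc1O` gives 14100 nM in this assay, and compound 3 `O=C(NNC(=O)c1ccccc1F)c1ccc(NS(=O)(=O)c2cnc(O)nc2O)cc1` gives 16000 nM. Among the three numbers compound 2 holds the second highest; its gap to compound 3 and its gap to compound 1 both lie within the scatter, so no order among them can be claimed.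

Compound 4 `Cc1ccc(C(=O)NNC(=O)c2ccccc2NS(=O)(=O)c2cnc(O)nc2O)cc1` has not yet been measured. It differs from compound 2 in one place: (4-methylphenyl)carbonyl in place of 2-chlorophenyl on an amine nitrogen. Going by the values given here, one measured step bears on this kind of change. In that step, going from compound 1 to compound 3, the result was a 2.2-fold higher number from compound 1 to compound 3 (0.34 log units; beyond the scatter), a modest weakening that just clears the scatter.

Because the step of a 2.2-fold higher number from compound 1 to compound 3 (0.34 log units; beyond the scatter) was modest, a similar shift toward weaker inhibition is expected for compound 4, with the caveat that the carbonyl-bearing group entering here carries a methyl rather than a fluorine. The expected step from compound 2 to compound 4 is therefore a 1.6-fold higher number from compound 2 to compound 4 (0.19 log units; within the scatter). Compound 4 is estimated at 22000 nM in this assay, within a range of 9000 nM to 50000 nM.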

Compound 4, half-maximal inhibitory concentration: 12900 nM
Beside the measured number, compound 4's estimate is 1.7-fold (0.23 log units) above it, within the range that was stated.
By their numbers in this assay, from the lowest: compounds 1, 4, 2 and 3 (each within the scatter of the next, the first and the last beyond it).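

In this assay the exchange of 2-chlorophenyl for (4-methylphenyl)carbonyl on the amine nitrogen gives a 1.1-fold lower number from compound 2 to compound 4 (0.04 log units; within the scatter) and so shows no readable change on the core of compound 2. The earlier step of this kind, a 2.2-fold higher number from compound 1 to compound 3 (0.34 log units; beyond the scatter) with (2-fluorophenyl)carbonyl entering on the core of compound 1, lay beyond the scatter, so an aryl carbonyl group entering at this nitrogen does not shift the number the same way in both pairs. Nothing measured here accounts for the contrast between the two steps.

On these data alone, it remains open whether (4-methylphenyl)carbonyl would give the same result on the core of compound 1, where the two cores could be compared directly. Also open, as far as these compounds go, is how an amine, a carboxylic acid or a longer alkyl chain would fare on this nitrogen.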